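This account rests on a few compounds, and the source may have more. Where it says the series, first, only, none or still open, it means among the compounds named here.

Compound 1 `O=C(CCCCCCc1cn(-c2ccccc2-c2ccccc2)nn1)NCc1cccnc1` gives 98% in a functional assay on SH-SY5Y cells (Homo sapiens) for cytotoxicity, read by MTT assay, with a stated time of 48 h, tested at 1 uM; on this read-out higher numbers stand for a weaker effect at the one concentration tested and lower numbers for a stronger effect.
Compound 2 `O=C(CCCCCCCc1cn(-c2ccccc2-c2ccccc2)nn1)Nc1ccncc1` gives 82% in this assay.
Compound 3 `O=C(CCCCCCCCc1cn(-c2cnc3ccccc3c2)nn1)Nc1ccncc1` gives 104% in this assay.

On these three numbers compound 2 stands lowest, with compound 1 the nearest and compound 3 the furthest, both beyond the scatter. Compound 4 `O=C(CCc1cccnc1)NCCCCCc1cn(-c2ccccc2-c2ccccc2)nn1` has the same atoms as compound 2, joined differently: a group of 11 heavy atoms (8 carbon, 2 nitrogen, 1 oxygen; one six-membered aromatic ring with 1 hetero atom) in place of a group of 11 heavy atoms (8 carbon, 2 nitrogen, 1 oxygen; one six-membered aromatic ring with 1 hetero atom), on a saturated chain carbon, five bonds along the chain from an aromatic carbon. Within the data shown here, only one measured step concerns the amide end of the chain, a number 16 percentage points lower from compound 1 to compound 2 (beyond the scatter), a modest step, and it ran from a group carrying pyridin-3-yl to one carrying pyridin-4-yl. Compound 4 again carries a pyridin-3-yl group, so a modest step back toward the numbers of compound 1 and compound 3 is expected, a number 13 percentage points higher from compound 2 to compound 4 (beyond the scatter). Compound 4 is therefore estimated at 95%, with a range from 80% to 110%.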

Compound 4, a percentage reported as activity, at one concentration (the size of the read-out at that concentration, not a potency): 54%
The estimate for compound 4 lay 41 percentage points above the measured number; measured number below the stated range.
By their numbers in this assay, from the lowest: compound 4; then compound 2; then compounds 1 and 3 (each within the scatter of the next).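

Rejoining the same atoms so that ((2-(pyridin-3-yl)ethyl)carbonyl)amino stands on a saturated chain carbon, five bonds along the chain from an aromatic carbon, gives a number 28 percentage points lower from compound 2 to compound 4 (beyond the scatter) in this assay and shows that the arrangement of the amide along the chain matters on this read-out, not only the composition. The pyridin-3-yl group alone does not keep the number high, as a number 44 percentage points lower from compound 1 to compound 4 (beyond the scatter) shows. No evidence is available on what lies behind this change.

As far as these compounds go, it remains open whether a pyridin-4-yl group in this arrangement would move the number further. From the compounds shown here alone, it also remains open how a carboxylic acid or a longer chain at this position would read.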